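Adding One Carbon to an Ester Side Chain

The source may report more compounds than this note shows. Statements on the series, on what has been measured and on what is new or still open speak of the compounds shown alone.

Compound 1, `CCCCCCCC(=O)NCC(C)(C)CC1=C(O)C(=O)c2ccccc2C1=O`, gives 24600 nM in a functional assay on KB cells (Homo sapiens) for cytotoxicity, read by resazurin assay, with a stated time of 3 days; on this read-out lower numbers stand for stronger inhibition and higher numbers for weaker inhibition.
Compound 2, `CCCCCCC(C)C(=O)NCC(C)(C)CC1=C(O)C(=O)c2ccccc2C1=O`, gives 23700 nM in this assay.
Compound 3, `CCCCCC(=O)OCC(C)(C)CC1=C(O)C(=O)c2ccccc2C1=O`, gives 41000 nM in this assay.

Compound 2 differs from compound 1 by methyl in place of hydrogen on a saturated chain carbon bound to a carbonyl carbon and a saturated chain carbon, and this change made a step of a 1.0-fold lower number from compound 1 to compound 2 (0.02 log units; within the scatter). Compound 3 carries an ester in place of the amide of compound 1; the difference between the two cores is not broken down here. Compound 4, `CCCCCCC(=O)OCC(C)(C)CC1=C(O)C(=O)c2ccccc2C1=O`, has not yet been measured. It differs from compound 3 by methyl in place of hydrogen on a saturated chain carbon, five bonds along the chain from a carbonyl carbon. Going by the values given here, this is the same kind of change as the one from compound 1 to compound 2, but at a different place: there the methyl entered on a saturated chain carbon bound to a carbonyl carbon and a saturated chain carbon, here it enters on a saturated chain carbon five bonds along the chain from a carbonyl carbon. Among the compounds with values here, since the only measured example of this kind of change, the step of a 1.0-fold lower number from compound 1 to compound 2 (0.02 log units; within the scatter), stayed within the scatter, compound 4 is expected to land close to compound 3, with an estimated step of a 1.1-fold lower number from compound 3 to compound 4 (0.03 log units; within the scatter). The estimate for compound 4 in this assay is therefore 38000 nM, with a likely range from 19000 nM to 76000 nM.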

Compound 4, half-maximal inhibitory concentration: 14400 nM
For compound 4 the middle estimate is 2.6-fold (0.42 log units) above the measured one; the whole stated range lies above it.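

In this assay, the added methyl brings a 2.8-fold lower number from compound 3 to compound 4 (0.45 log units; beyond the scatter), so on the ester core this small change does shift the result, though only modestly. The same kind of change does not carry over unchanged from the amide core to the ester core: the same change on two cores in this assay, a 1.0-fold lower number (0.02 log units; within the scatter) from compound 1 to compound 2 and a 2.8-fold lower number (0.45 log units; beyond the scatter) from compound 3 to compound 4, 2.7-fold (0.44 log units) apart, beyond the scatter of two such steps. Going by these compounds alone, this does not show that the core alone sets the size of the step: the methyl sits on a saturated chain carbon bound to a carbonyl carbon and a saturated chain carbon in compound 2, but on a saturated chain carbon, five bonds along the chain from a carbonyl carbon, in compound 4, and each core supplies only one pair.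

The compounds shown leave open whether a methyl at the compound 2 place would give the same step on the ester core. They also leave open whether a longer chain on the ester would lower the number further or whether the trend would stop at compound 4.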